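This account rests on a few compounds, and the source may have more. Where it says the series, first, only, none or still open, it means among the compounds named here.

Measured in a functional assay on MDA-MB-231 cells (Homo sapiens) for cytotoxicity, read by sulforhodamine B assay, with a stated time of 48 h; a lower number here means a stronger inhibitor of growth, a higher number a weaker inhibitor of growth:
compound 1 `CCN(CC)CN1C(=O)/C(=N\c2nc3ccc(C)cc3s2)c2ccccc21` gives 32700 nM
compound 2 `Cc1ccc2nc(/N=C3\C(=O)N(CN4CCCCC4)c4ccccc43)sc2c1` gives 34500 nM
compound 3 `Cc1ccc2nc(/N=C3\C(=O)N(CN(C)C)c4ccccc43)sc2c1` gives 19200 nM

Compound 3 has the lowest of the three numbers, but the gaps to its neighbours are small: a 1.7-fold lower number from compound 1 to compound 3 (0.23 log units; within the scatter) and a 1.8-fold lower number from compound 2 to compound 3 (0.25 log units; within the scatter) both stay within the scatter, so the three compounds cannot be ranked against each other. Compound 4 `Cc1ccc2nc(/N=C3\C(=O)N(CN(C)C)c4cccc(Cl)c43)sc2c1` differs from compound 3 by chloro in place of hydrogen on an aromatic carbon. Within the data shown here, every measured step so far changed only the amine on the saturated chain carbon; none touched the aromatic carbons of the shared core, so no measured step bears directly on this change. Without a precedent, the expected step of a 1.0-fold lower number from compound 3 to compound 4 (0.00 log units; within the scatter) is none beyond the scatter, and compound 4 is estimated at 19000 nM in this assay, within a range of 6000 nM to 60000 nM.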

Compound 4, concentration for 50% growth inhibition: 10900 nM
Compound 4: middle estimate off by 1.7-fold (0.24 log units), on the high side; measured number inside the range.
By their numbers in this assay, from the lowest: compounds 4, 3, 1 and 2 (each within the scatter of the next, the first and the last beyond it).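

In this assay, among these compounds, chloro in place of hydrogen on an aromatic carbon gives a 1.8-fold lower number from compound 3 to compound 4 (0.25 log units; within the scatter) and is the first measured change away from the amine, showing that this carbon of the shared core can carry a chlorine atom with no step distinguishable from the scatter. No available evidence bears on this result.

On these data alone, whether methoxy or a carboxylic acid on the same carbon would give a step beyond the scatter remains open. So does whether chloro would behave alike on the ring's other aromatic carbons.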